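Aryl group exchange in the series: working notes

The source may hold more compounds than are shown below. What is called first, only, known or untested is meant among the compounds shown, and "the series" means these compounds.

In a physicochemical assay for lipophilicity (a higher number here means a more lipophilic compound, a lower number a more polar compound), compound 1 `C[C@H]1CC[C@@H]2[C@@H](OC(=O)[C@]23CC(c2ccccc2[N+](=O)[O-])=NO3)[C@]2(C)C(=O)C=C[C@@]12O` gives 1.37 and compound 2 `C[C@H]1CC[C@@H]2[C@@H](OC(=O)[C@]23CC(c2ccc([N+](=O)[O-])cc2)=NO3)[C@]2(C)C(=O)C=C[C@@]12O` gives 1.37, with no change at the digits printed from compound 1 to compound 2 (within the scatter). Compound 3 `COc1cc(C2=NO[C@]3(C2)C(=O)O[C@@H]2[C@H]3CC[C@H](C)[C@]3(O)C=CC(=O)[C@@]23C)ccc1O`, at 0.75, is the lowest of these three on this assay.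

The next compound to consider is compound 4 `C[C@H]1CC[C@@H]2[C@@H](OC(=O)[C@]23CC(c2ccccc2Cl)=NO3)[C@]2(C)C(=O)C=C[C@@]12O`, not yet measured. The change is 2-chlorophenyl in place of 4-hydroxy-3-methoxyphenyl on a carbon with a double bond to nitrogen, with the rest of the core shared.

Two measured steps make an exchange on that same carbon: a number 0.62 log units lower from compound 1 to compound 3 (beyond the scatter) and a number 0.62 log units lower from compound 2 to compound 3 (beyond the scatter). Both are modest and beyond the scatter. Each ends at the group that compound 4 gives up, but each starts from a nitrophenyl group. Among the measured compounds shown here, no measured compound carries 2-chlorophenyl, so these steps serve only as a guide. Read in reverse, they point to a rise on this assay of similar or somewhat larger size, beyond the scatter. The expected step is a number 0.85 log units higher from compound 3 to compound 4 (beyond the scatter). Compound 4 is estimated at 1.6, with an expected range from 1.2 to 2.1.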

Compound 4, partition coefficient: 2.09
Beside the measured number, compound 4's estimate is 0.49 log units below it; low and high end bracket the measured number.
By their numbers in this assay, from the lowest: compound 3; then compounds 1 and 2 (each within the scatter of the next); then compound 4.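

In this assay, the exchange at this carbon now reaches above the two nitrophenyl compounds as well as above the 4-hydroxy-3-methoxyphenyl compound, with 2-chlorophenyl in place of 4-nitrophenyl giving a number 0.72 log units higher from compound 2 to compound 4 (beyond the scatter). The closest comparison is chloro in place of nitro on an aromatic carbon, which gives a number 0.72 log units higher from compound 1 to compound 4 (beyond the scatter), so this position separates the two substituents even though the shift of nitro from 2-nitrophenyl to 4-nitrophenyl showed no separation; the widest exchange so far at this carbon, and the only large one, is a number 1.34 log units higher from compound 3 to compound 4 (beyond the scatter). That widest exchange removes 1 hydrogen-bond donor and 2 hydrogen-bond acceptors along with the change in heavy atoms, and nothing available accounts for the size of the rise or assigns it to any one part of the exchange.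

The compounds shown leave open whether 4-chlorophenyl would stand level with 2-chlorophenyl, as the two nitrophenyl groups stand level with each other. They also leave open where an unsubstituted phenyl, or a phenyl carrying an amine or a carboxylic acid, would fall on this assay.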